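The source may report more compounds than this note shows. Statements on the series, on what has been measured and on what is new or still open speak of the compounds shown alone.

Compound 1 `CCCCCCCCN(C)C(=O)Cn1cc(Cc2cnc(OC)nc2)c(=O)nc1SCc1ccc(F)cc1`: 13% in a functional assay on a cell-free system (plasma, Oryctolagus cuniculus) for inhibition of platelet-activating factor acetylhydrolase (Homo sapiens), tested at 100 nM; a higher number here means more inhibition at the concentration tested (going by the name of the read-out), a lower number less inhibition
Compound 2 `CCCCCCCCN(C)C(=O)Cn1cc(Cc2cnc(O)nc2)c(=O)nc1SCc1ccc(F)cc1`: 34%
Compound 3 `CCCCCCCCN(C)C(=O)Cn1cc(Cc2cnc(=O)n(CC)c2)c(=O)nc1SCc1ccc(F)cc1`: 5%

Compound 3 gives the lowest of the three numbers: the step of a number 8 percentage points lower from compound 1 to compound 3 (within the scatter) lies within the scatter, while the step of a number 29 percentage points lower from compound 2 to compound 3 (beyond the scatter) is beyond it, as is a number 21 percentage points higher from compound 1 to compound 2 (beyond the scatter). Compound 4 `CCCCCCCCN(C)C(=O)Cn1cc(Cc2cnc(=O)n(CC(=O)N3CCOCC3)c2)c(=O)nc1SCc1ccc(F)cc1` differs from compound 3 only by (morpholin-4-yl)carbonyl in place of methyl on a saturated chain carbon bound to an aromatic nitrogen. Among the measured compounds shown here, no measured step alters that part of the structure; the three known steps all concern the group on the saturated chain carbon bound to an aromatic carbon, so they give only indirect guidance. Compound 3 already sits near the bottom of the range, and compound 4 is therefore expected to show a step of a number 5 percentage points higher from compound 3 to compound 4 (within the scatter), not beyond the scatter. Compound 4 is estimated at 10%, in a range from 0% to 30%.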

Compound 4, a percentage reported as inhibition, at one concentration (the size of the read-out at that concentration, not a potency): 36%
For compound 4 the middle estimate is 26 percentage points below the measured one, outside the stated range (above it).
By their numbers in this assay, from the lowest: compounds 3 and 1 (each within the scatter of the next); then compounds 2 and 4 (each within the scatter of the next).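

In this assay there is a number 31 percentage points higher from compound 3 to compound 4 (beyond the scatter) with (morpholin-4-yl)carbonyl in place of methyl on a saturated chain carbon bound to an aromatic nitrogen. This is the first change at this place among the compounds shown, and it shows that the read-out responds to the group there. No measurement at hand accounts for the step. From the compounds shown here alone, it remains open whether the morpholine ring or the carbonyl carries the step, and a dimethylamide or a carboxylic acid at this place would help separate the two.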